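The compounds below may be only part of what the source reports. "The series", "measured", "known", "first", "only" and "open" are said of these compounds alone.

Working notes on the series. Compound 1 `O=c1[nH]cc(S(=O)(=O)Nc2ccc(-c3cn(-c4ccccc4)nn3)cc2)c(=O)[nH]1` gives 18800 nM in a functional assay on SGC-7901 cells (Homo sapiens) for antiproliferative activity, read by MTT assay, with a stated time of 24 h; on this read-out higher numbers stand for weaker inhibition and lower numbers for stronger inhibition. Compound 2 `Cc1cccc(-n2cc(-c3ccc(NS(=O)(=O)c4c[nH]c(=O)[nH]c4=O)cc3)nn2)c1` gives 17500 nM in this assay, and the step of a 1.1-fold lower number from compound 1 to compound 2 (0.03 log units; within the scatter) is a methyl in place of hydrogen on an aromatic carbon. Compound 3 `O=c1[nH]cc(S(=O)(=O)Nc2ccc(-c3cn(-c4ccc(F)cc4)nn3)cc2)c(=O)[nH]1` reaches only the limit of this assay, > 20000 nM. Its position is thus fixed by the limit of > 20000 nM in this assay, at which 1 of the 3 values shown sits, alone, and the steps of an at least 1.0-fold higher number from compound 1 to compound 3 (0.02 log units; that floor lies within the scatter) and an at least 1.1-fold higher number from compound 2 to compound 3 (0.05 log units; that floor lies within the scatter) set it apart from the others by nothing beyond the scatter.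

Compound 4 `O=c1[nH]cc(S(=O)(=O)Nc2ccc(-c3cn(-c4ccccc4Cl)nn3)cc2)c(=O)[nH]1` differs from compound 3 by 2-chlorophenyl in place of 4-fluorophenyl on an aromatic nitrogen. Among the measured compounds shown here, the one measured step of this kind, an aryl swap on that nitrogen, was an at least 1.1-fold higher number from compound 2 to compound 3 (0.05 log units; that floor lies within the scatter), within the scatter, so no step beyond the scatter in this assay is expected. Compound 4 is therefore estimated at 22000 nM, with a range from 12000 nM to 45000 nM. This estimate corresponds to a step that the limit leaves unreadable from compound 3 to compound 4, and the assay may again report only its limit.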

Compound 4, half-maximal inhibitory concentration: 2680 nM
The estimate for compound 4 lay 8.2-fold (0.91 log units) above the measured number; the measured number lies below the stated range.
By their numbers in this assay, from the lowest: compound 4; then compounds 2 and 1 (each within the scatter of the next). At a limit, above all of these: compound 3.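

In this assay, among the compounds shown here, the 2-chlorophenyl on the aromatic nitrogen gives the first steps that lie beyond the scatter: a 7.0-fold lower number from compound 1 to compound 4 (0.85 log units; beyond the scatter) and a 6.5-fold lower number from compound 2 to compound 4 (0.81 log units; beyond the scatter). This aryl position can therefore respond to a change of group, which the near-equal values of compounds 1 and 2 did not show. The step of an at least 7.4-fold lower number from compound 3 to compound 4 (0.87 log units; beyond the scatter) is only a floor, as compound 3 stands at a limit: the limit of > 20000 nM in this assay, at which 1 of the 4 values shown sits.

The compounds shown do not separate the effect of the chlorine itself from that of where it sits on the phenyl. Going by these compounds, how a methoxy group or an amine on that phenyl would read remains open.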